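The source may hold more compounds than are shown below. What is called first, only, known or untested is meant among the compounds shown, and "the series" means these compounds.

Compound 1, `Cc1cc(NC(=O)CN2CCC(c3cccc[n+]3[O-])CC2)ccc1F`, gives 75% in a functional assay on HEK293 cells for agonist activity at D(4) dopamine receptor (Homo sapiens), read by FLIPR; a higher number here means a larger maximal response, a lower number a smaller maximal response. That is the highest of the three numbers in hand: compound 2, `Cc1cccc(NC(=O)CN2CCC(c3nccs3)CC2)c1`, gives 62% in this assay, and compound 3, `Cc1cccc(NC(=O)CN2CCC(c3ccccc3F)CC2)c1`, gives 57% in this assay. Both of those lie beyond the scatter below compound 1. Within the data shown here, the only measured step that changes one place, the move a number 5 percentage points lower from compound 2 to compound 3 (within the scatter), concerns the saturated ring carbon and lies within the scatter.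

Compound 4, `Cc1cc(F)ccc1NC(=O)CN1CCC(c2cccc[n+]2[O-])CC1`, has the same atoms as compound 1 joined differently: 4-fluoro-2-methylphenyl in place of 4-fluoro-3-methylphenyl on an amide-type nitrogen. Among the measured compounds shown here, no measured step touches the aromatic group on the amide-type nitrogen, so there is nothing to set a direction for this change; the one step in hand, between compound 2 and compound 3, was small, and a small step is the likeliest outcome here too. Compound 4 is therefore expected to give about 70% in this assay, with a plausible range from 50% to 88%, which means an expected step of a number 5 percentage points lower from compound 1 to compound 4 (within the scatter) that may not exceed the scatter.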

Compound 4, largest response reached (reported as efficacy), in percent of the reference or control that the assay uses: 84%
Beside the measured number, compound 4's estimate is 14 percentage points below it; the range from low to high includes it.
By their numbers in this assay, from the lowest: compounds 3 and 2 (each within the scatter of the next); then compounds 1 and 4 (each within the scatter of the next).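

Among these compounds, putting 4-fluoro-2-methylphenyl in place of 4-fluoro-3-methylphenyl on the amide-type nitrogen gives a number 9 percentage points higher from compound 1 to compound 4 (within the scatter) in this assay, the first measured step at this position. The two arrangements of the same atoms therefore cannot be told apart by their maximal response, and this one change at the aromatic group leaves the response within the scatter. Nothing available offers a reason for this result.

From the compounds shown here alone, it remains open whether a larger change on this aromatic group would move the response beyond the scatter, for instance a carboxylic acid or an aminomethyl group in place of the methyl. Going by these compounds, it is also open whether the same exchange would give a similar step with 1,3-thiazol-2-yl or 2-fluorophenyl on the saturated ring carbon.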